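The source may report more compounds than this note shows. Statements on the series, on what has been measured and on what is new or still open speak of the compounds shown alone.

Measured in a functional assay on MKN-45 cells (Homo sapiens) for cytotoxicity, read by MTT assay, with a stated time of 72 h; a higher number here means a weaker inhibitor, a lower number a stronger inhibitor:

compound 1 `COc1cc2c(Oc3ccc(NC(=O)c4cc(-c5cccc(Cl)c5)nc5ccccc45)cc3F)ccnc2cc1OCCCN1CCC(C)CC1`: 30 nM
compound 2 `COc1cc2c(Oc3ccc(NC(=O)c4cc(-c5ccccc5)nc5ccccc45)cc3F)ccnc2cc1OCCCN1CCC(C)CC1`: 19 nM
compound 3 `COc1cc2c(Oc3ccc(NC(=O)c4cc(-c5ccccc5)nc5ccc(F)cc45)cc3F)ccnc2cc1OCCCN1CCCC1`: 110 nM

Compound 3 gives the highest of the three numbers. The difference between the core of compound 3 and the core of compound 2 is not broken down here; the two values alone show that compound 3 gives a weaker result in this assay than compound 2 and than compound 1.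

Within the core of compound 2, the change chloro in place of hydrogen on an aromatic carbon gives the step of a 1.6-fold higher number from compound 2 to compound 1 (0.20 log units; within the scatter). The unmeasured compound 4 `COc1cc2c(Oc3ccc(NC(=O)c4cc(-c5cccc(Cl)c5)nc5ccc(F)cc45)cc3F)ccnc2cc1OCCCN1CCCC1` carries the same change on the core of compound 3: chloro in place of hydrogen on an aromatic carbon. The place lines of the two changes read the same word for word, so this is the same change, seen once more on a different core.

Going by the values given here, for compound 4 in this assay the expected step is a 1.5-fold higher number from compound 3 to compound 4 (0.16 log units; within the scatter), resting on the one earlier instance, a 1.6-fold higher number from compound 2 to compound 1 (0.20 log units; within the scatter), which stayed within the scatter. Because compound 3 gives 110 nM, compound 4 is estimated at 160 nM, with a range from 70 nM to 360 nM.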

Compound 4, half-maximal inhibitory concentration: 67 nM
Compound 4: middle estimate off by 2.4-fold (0.38 log units), on the high side; measured number below the stated range.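

On the core of compound 3, the change from phenyl to 3-chlorophenyl gives a 1.6-fold lower number from compound 3 to compound 4 (0.22 log units; within the scatter) in this assay, and the two instances can be set side by side: the same change on two cores in this assay, a 1.6-fold higher number (0.20 log units; within the scatter) from compound 2 to compound 1 and a 1.6-fold lower number (0.22 log units; within the scatter) from compound 3 to compound 4, 2.6-fold (0.41 log units) apart, within the scatter of two such steps. The change therefore carries across these two cores as a step that stays within the scatter, and the opposite directions of the two numbers show no real difference between the cores. This does not show that chloro is without effect on every core in the series, since it rests on two pairs only, and it gives no reading of what the other differences between the two cores contribute.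

The compounds shown leave open whether a group other than chloro, such as methoxy, trifluoromethyl or nitrile, would also give a step within the scatter when placed on the same ring. Going by these compounds, it also remains open whether the chloro step would hold with a different amine at the end of the chain, such as morpholine or piperazine.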